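Heteroaryl thioether variation on the shared core

The source may hold more compounds than are shown below. What is called first, only, known or untested is meant among the compounds shown, and "the series" means these compounds.

Three members of the series have been measured in a functional assay on HCT-116 cells (Homo sapiens) for antiproliferative activity, read by MTT assay, with a stated time of 48 h; on this read-out lower numbers stand for stronger inhibition and higher numbers for weaker inhibition. Compound 1 `O=C(Nc1cc(Sc2ncnc3nc[nH]c23)c(O)c2ccccc12)c1ccc(Cl)cc1` returns only a limit in this assay, > 100000 nM. Compound 2 `O=C(Nc1cc(Sc2nncs2)c(O)c2ccccc12)c1ccc(Cl)cc1` likewise returns only a limit, > 100000 nM. Among the compounds with values here, compound 3 `O=C(Nc1cc(Sc2ncn[nH]2)c(O)c2ccccc12)c1ccc(Cl)cc1` is the single member with a number: in this assay compound 3 gives 43300 nM. Within the data shown here, the step of an at least 2.3-fold lower number from compound 2 to compound 3 (0.36 log units; beyond the scatter) is the one fully readable change, and an at least 2.3-fold lower number from compound 1 to compound 3 (0.36 log units; beyond the scatter) reads the same way; the step that the two limits leave unreadable from compound 1 to compound 2 cannot be sized because both of its ends sit at the limit of > 100000 nM in this assay, at which 2 of the 3 values shown sit.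

Compound 4 `Cn1nnnc1Sc1cc(NC(=O)c2ccc(Cl)cc2)c2ccccc2c1O` has not been measured. It differs from compound 3 by 1-methyl-1H-tetrazol-5-yl in place of 1H-1,2,4-triazol-5-yl on a sulfur. Among the measured compounds shown here, both readable steps concern the ring on the sulfur, and each has compound 3, the single member with a number, as its end point. For the measured compounds named here, with only one number on hand, the size of a further exchange of this ring is not fixed by them. The number for compound 4 is expected to remain in the weak range, with a step of a 1.4-fold higher number from compound 3 to compound 4 (0.14 log units; within the scatter) that need not exceed the scatter. Compound 4 is therefore estimated at 60000 nM, between 20000 nM and 200000 nM.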

Compound 4, half-maximal inhibitory concentration: > 100000 nM
Compound 4 was reported as a limit; the forecaster's own chance of this, stated with the estimate: 40%; middle value at least 1.6-fold (0.22 log units) from the limit.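

In this assay, within the data shown here, 1-methyl-1H-tetrazol-5-yl in place of 1H-1,2,4-triazol-5-yl on the sulfur gives an at least 2.3-fold higher number from compound 3 to compound 4 (0.36 log units; beyond the scatter), so a ring exchange at this position now also leads away from the only compound with a number, where the earlier readable steps led towards it. The leaving group has 1 hydrogen-bond donor and 2 hydrogen-bond acceptors and the entering group has 0 hydrogen-bond donors and 4 hydrogen-bond acceptors, with a methyl and a further ring nitrogen as well, and this one pair does not separate these differences. The remaining steps among compound 1, compound 2 and compound 4 cannot be read, and the series now gathers at a single assay limit: the limit of > 100000 nM in this assay, at which 3 of the 4 values shown sit.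

Going by these compounds, it remains open whether 1H-tetrazol-5-yl or 1-methyl-1H-1,2,4-triazol-5-yl would read like compound 3 or like compound 4, a pair of cases that would separate the methyl from the ring. All groups shown on this sulfur are aromatic rings, and an open-chain group such as aminoethyl or carboxymethyl remains an open case.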